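The source may report more compounds than this note shows. Statements on the series, on what has been measured and on what is new or still open speak of the compounds shown alone.

Measured compounds:
compound 1 `COc1ccc(-c2cnc(NC(=O)c3ccco3)n2C)cc1` — in a toxicity assay on THP-1 cells (Homo sapiens) for inhibition (on this read-out higher numbers stand for lower toxicity in this test and lower numbers for higher toxicity in this test), compound 1 gives > 100000 nM, a limit of the test.
compound 2 `COc1ccc(-c2cnc(NC(=O)c3ccc(F)cc3)n2-c2ccccc2)cc1` — in this assay compound 2 gives 8800 nM.

Among the measured compounds shown here, compound 2 is the only compound with a plain number in this assay, the other value being a limit (the limit of > 100000 nM in this assay, at which 1 of the 2 values shown sits). Compound 3 `COc1ccc(-c2cnc(NC(=O)c3ccc(F)cc3)n2C)cc1` has not yet been measured in this assay. It differs from compound 2 in one place, (methyl in place of phenyl on an aromatic nitrogen). For the measured compounds named here, no step between two measured compounds is available for this change, so the size is uncertain. A step toward higher numbers, beyond the scatter, is expected from compound 2 to compound 3, of about a 4.0-fold higher number from compound 2 to compound 3 (0.60 log units; beyond the scatter). Compound 3 is estimated at 35000 nM, within 9000 nM to 150000 nM.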

Compound 3, half-maximal cytotoxic concentration: >= 50000 nM
Compound 3: a limit, no number; the forecaster's own chance of this, stated with the estimate: 40%; middle value at least 1.4-fold (0.15 log units) away from the limit.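

Methyl in place of phenyl on the aromatic nitrogen gives an at least 5.6-fold higher number from compound 2 to compound 3 (0.75 log units; beyond the scatter) in this assay, the first readable step at this position. This size is only a bound, as compound 3 gives a limit and not a number: the limit of >= 50000 nM in this assay, at which 1 of the 3 values shown sits. Among the compounds shown here, the only step from compound 1, 4-fluorophenyl in place of furan-2-yl on a carbonyl carbon, cannot be read, as both values are limits. Going by these compounds, what remains open is the actual number for compound 3, and how an ethyl or a benzyl group on that aromatic nitrogen would read in this assay.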